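The source may report more compounds than this note shows. Statements on the series, on what has been measured and on what is new or still open speak of the compounds shown alone.

Measured compounds:
compound 1 `O=C(Nc1ccc2nc(NC(=O)C3CCCCC3)sc2c1)c1ccccc1F` — 0.14 ug/mL
compound 2 `O=C(Nc1ccc2nc(NC(=O)C3CCCCC3)sc2c1)c1ccccc1C(F)(F)F` — 0.024 ug/mL
compound 3 `O=C(Nc1nc2ccc(NC(=O)C3CCCO3)cc2s1)C1CCCCC1` — 1.3 ug/mL

In a functional assay on WI-38 VA13 cells (Homo sapiens) for cytotoxicity (a higher number here means that more compound is needed for the effect, a lower number that less compound is needed), compound 1 stands second highest of the three numbers. Its nearest neighbour is compound 2, reached by a 5.8-fold lower number from compound 1 to compound 2 (0.77 log units; beyond the scatter); the furthest is compound 3, reached by a 9.3-fold higher number from compound 1 to compound 3 (0.97 log units; beyond the scatter). Compound 4 `Cc1cccc(C)c1NC(=O)Nc1ccc2nc(NC(=O)C3CCCCC3)sc2c1` arises from compound 1 by one change: (2,6-dimethylphenyl)amino in place of 2-fluorophenyl on a carbonyl carbon. Both earlier steps changed the same carbonyl substituent, and both moved the number modestly, in opposite directions. Compound 4 keeps an aromatic ring, unlike compound 3, so a modest shift is expected, with direction uncertain; I expect a 1.8-fold higher number from compound 1 to compound 4 (0.25 log units; within the scatter). For compound 4 the estimate in this assay is 0.25 ug/mL, within 0.05 ug/mL to 1.2 ug/mL.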

Compound 4, half-maximal effective concentration: 0.56 ug/mL
Compound 4: the middle estimate sits 2.2-fold (0.35 log units) below what was measured; the measured number falls inside the stated range.
By their numbers in this assay, from the lowest: compound 2; then compound 1; then compound 4; then compound 3.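

In this assay, an aromatic ring on this carbonyl carbon does not by itself keep the number low: (2,6-dimethylphenyl)amino gives a 4.0-fold higher number from compound 1 to compound 4 (0.60 log units; beyond the scatter), and against the 2-(trifluoromethyl)phenyl group it gives a 23-fold higher number from compound 2 to compound 4 (1.37 log units; beyond the scatter). It still needs less compound than oxolan-2-yl, with a 2.3-fold lower number from compound 3 to compound 4 (0.37 log units; beyond the scatter). Nothing measured here explains these shifts. The change swaps a directly attached ring for one joined through an amino nitrogen and adds two methyl groups, so the contribution of each remains unresolved. A plain phenylamino group on this carbonyl carbon would help separate them.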